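Fluoro for Methyl on the Aryl Ring of Compound 2

The compounds below may be only part of what the source reports. "The series", "measured", "known", "first", "only" and "open" are said of these compounds alone.

Compound 1, `Cc1ccc([C@@H]2NC[C@H](O)[C@H]2O)cc1`: in an assay on lysosomes for inhibition of Maltase-glucoamylase (Homo sapiens), read by spectrophotometry, tested at 1000 uM (a higher number here means more inhibition at the concentration tested (going by the name of the read-out), a lower number less inhibition), compound 1 gives 4.8%.
Compound 2, `Cc1ccc([C@H]2NC[C@@H](O)[C@@H]2O)cc1`: in this assay compound 2 gives 15%.

For the measured compounds named here, compound 2 stands highest of the two measured numbers, with compound 1 as its only neighbour; the step of a number 10.2 percentage points higher from compound 1 to compound 2 (beyond the scatter) rests on (the fact that compounds 1 and 2 differ only in the configuration as drawn). Compound 3, `O[C@H]1[C@H](O)CN[C@@H]1c1ccc(F)cc1`, is not yet measured. It differs from compound 2 as follows: fluoro in place of methyl on an aromatic carbon. Going by the values given here, no measured step bears on this change, the one known step being an inversion of configuration alone, so no step beyond the scatter is foreseen. The expected step is no change at the digits printed from compound 2 to compound 3 (within the scatter). For compound 3 the estimate is 15%, between 3% and 30%.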

Compound 3, a percentage reported as inhibition, at one concentration (the size of the read-out at that concentration, not a potency): 13.4%
Compound 3: the middle estimate sits 1.6 percentage points above what was measured, within the range that was stated.
By their numbers in this assay, from the lowest: compounds 1, 3 and 2 (each within the scatter of the next, the first and the last beyond it).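

In this assay, fluoro in place of methyl on the aromatic carbon gives a number 1.6 percentage points lower from compound 2 to compound 3 (within the scatter), so at this place the two groups cannot be told apart. For the compounds shown here, the earlier pair showed only a step from inverting every stereocentre, whereas this is the first reading on a change of group on the aromatic ring. Nothing in the available evidence bears on this result.

As far as these compounds go, what a methoxy group, an amine or a carboxylic acid would do at this place remains open. So does whether fluoro would read the same on the mirror-image configuration of compound 1.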